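A few compounds are considered here, and "the series" means these few. Any claim that something is new, unique, unknown or untested is made for them only; others in the source may bear on it.

Compound 1 `CCCOc1ccc(C)c(-c2cccc(COc3ccc(OCC(=O)O)c(F)c3)c2)c1` carries a propoxy group on the core that it shares with compound 2 `Cc1ccc(OCC(C)C)cc1-c1cccc(COc2ccc(OCC(=O)O)c(F)c2)c1` and compound 3 `Cc1ccc(OCC2CCCCC2)cc1-c1cccc(COc2ccc(OCC(=O)O)c(F)c2)c1`. In a functional assay on CHO cells for agonist activity at Free fatty acid receptor 1 (Homo sapiens), read by FLIPR and calcium flux (a lower number here means that less compound is needed, a higher number that more compound is needed for the effect), compound 1 gives 610 nM, the lowest of the three numbers; compound 3 gives 910 nM and compound 2 gives 1450 nM. The step of a 1.5-fold higher number from compound 1 to compound 3 (0.17 log units; within the scatter) shows that cyclohexyl in place of ethyl on a saturated chain carbon bound to an oxygen on an aromatic ring left the number within the usual scatter, whereas a 2.4-fold higher number from compound 1 to compound 2 (0.38 log units; beyond the scatter) shows a modest rise for methyl in place of hydrogen on a saturated chain carbon. Between the two larger groups the step is a 1.6-fold lower number from compound 2 to compound 3 (0.20 log units; within the scatter).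

Compound 4 `Cc1ccc(OCCC2CCCCC2)cc1-c1cccc(COc2ccc(OCC(=O)O)c(F)c2)c1` differs from compound 1 in one place: cyclohexyl in place of methyl on a saturated chain carbon, two bonds along the chain from an oxygen on an aromatic ring. Read one bond further out, the change is propoxy to 2-cyclohexylethoxy. The step from compound 1 to compound 3 bears most directly on it, as that step also brought a cyclohexyl onto this chain and stayed within the scatter; the branching step from compound 1 to compound 2 is less comparable, yet it shows no lowering of the number on enlarging the chain. Compound 4 is therefore expected to show a step of a 1.3-fold higher number from compound 1 to compound 4 (0.12 log units; within the scatter), a small rise at most. The estimate for compound 4 in this assay is 800 nM, within 350 nM to 1800 nM.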

Compound 4, half-maximal effective concentration: 520 nM
For compound 4 the middle estimate is 1.5-fold (0.19 log units) above the measured one, within the range that was stated.
By their numbers in this assay, from the lowest: compounds 4, 1, 3 and 2 (each within the scatter of the next, the first and the last beyond it).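

The chain at this position accepts cyclohexyl in place of methyl, on a saturated chain carbon two bonds along the chain from an oxygen on an aromatic ring: in this assay the step is a 1.2-fold lower number from compound 1 to compound 4 (0.07 log units; within the scatter) and so gives no separation between the propoxy and 2-cyclohexylethoxy groups, which shows that this larger ring-bearing chain can stand here with no loss beyond the scatter. Cyclohexylmethyl in place of cyclohexyl gives a 1.8-fold lower number from compound 3 to compound 4 (0.24 log units; within the scatter) and likewise does not separate those two compounds, whereas cyclohexylmethyl in place of isopropyl gives a 2.8-fold lower number from compound 2 to compound 4 (0.45 log units; beyond the scatter) and thus a modest gap beyond the scatter, which sets the 2-cyclohexylethoxy chain apart from the branched chain of compound 2 alone among the chains compared with it. Nothing in the available evidence accounts for these numbers.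

The compounds shown leave open whether a longer chain such as 3-cyclohexylpropoxy would keep the number at this level or move it beyond the scatter. They also leave open what a phenyl ring or an amine would do in place of the cyclohexyl on this chain.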